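The compounds below may be only part of what the source reports. "The series", "measured", "known", "first", "only" and "open" are said of these compounds alone.

Compound 1 `COC(=O)c1ccc(-c2nnn(CC(=O)C(C)Oc3ccc(Oc4ccc(C(F)(F)F)cc4)cc3)n2)cc1` is one of two compounds tested in an assay on microsomes from brain for inhibition of Fatty-acid amide hydrolase 1 (Rattus norvegicus), read by fluorescence and HPLC, with a stated time of 60 min (on this read-out lower numbers stand for stronger inhibition and higher numbers for weaker inhibition), in which compound 1 gives 130 nM. That is the highest of the two numbers shown. Within the data shown here, its neighbour, compound 2 `COC(=O)c1ccc(-c2nnn(CC(=O)C(C)Oc3ccc(-c4ccccc4)cc3)n2)cc1`, gives 23 nM in this assay, and the one measured step, a 5.7-fold lower number from compound 1 to compound 2 (0.75 log units; beyond the scatter), comes from exchanging phenyl for 4-(trifluoromethyl)phenoxy on an aromatic carbon.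

Compound 3 `CC(Oc1ccc(Oc2ccc(C(F)(F)F)cc2)cc1)C(=O)Cn1nnc(-c2ccc(C(=O)O)cc2)n1` has not yet been measured. It differs from compound 1 in a single place: hydrogen in place of methyl on an oxygen next to a carbonyl group, that is, methoxycarbonyl becomes carboxy on the shared core. Among the measured compounds shown here, no measured step in this set bears on that change; the only step recorded, from compound 1 to compound 2, alters a different part of the molecule, so it offers no guide here.

With nothing to lean on, the expectation for compound 3 is a step in this assay of a 3.1-fold higher number from compound 1 to compound 3 (0.49 log units; beyond the scatter), with wide uncertainty in either direction. Compound 3 is therefore estimated to give 400 nM in this assay, most likely falling between 100 nM and 2000 nM.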

Compound 3, half-maximal inhibitory concentration: 160 nM
The estimate for compound 3 lay 2.5-fold (0.40 log units) above the measured number; the measured number falls inside the stated range.
By their numbers in this assay, from the lowest: compound 2; then compounds 1 and 3 (each within the scatter of the next).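

In this assay, replacing methoxycarbonyl with carboxy on the shared core gives a 1.2-fold higher number from compound 1 to compound 3 (0.09 log units; within the scatter), so this read-out does not separate the two compounds. Among these compounds, the earlier pair showed only a change at the 4-(trifluoromethyl)phenoxy end, whereas this step gives the first reading at the other end of the molecule: with 4-(trifluoromethyl)phenoxy kept in place, hydrogen can stand in place of methyl on an oxygen next to a carbonyl group with no difference beyond the usual scatter. Nothing available here accounts for this result.

The compounds shown leave open whether the same exchange would also pass without a difference beyond the scatter on the core of compound 2, which gives 23 nM and carries phenyl in place of 4-(trifluoromethyl)phenoxy. They also leave open how this position would respond to a primary amide, a nitrile or an ester with a longer chain such as ethoxycarbonyl, since a single pair of methoxycarbonyl and carboxy marks out only a small part of what could stand there.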